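The compounds below may be only part of what the source reports. "The series", "measured", "known", "first", "only" and "open" are said of these compounds alone.

Measured so far in a functional assay on VCaP cells (Homo sapiens) for antiproliferative activity, read by propidium iodide staining, with a stated time of 96 h; a lower number here means a stronger inhibitor, a higher number a weaker inhibitor:
- compound 1 `CC(O)(CSc1ccccc1OC(F)(F)F)C(=O)Nc1ccc(S(F)(F)(F)(F)F)cc1` gives 10100 nM
- compound 2 `CC(O)(CSc1ccc(S(F)(F)(F)(F)F)cc1)C(=O)Nc1cccc(S(F)(F)(F)(F)F)c1` gives 24100 nM
- compound 3 `CC(O)(CSc1ccc(C(F)(F)F)cc1)C(=O)Nc1cccc(S(F)(F)(F)(F)F)c1` gives 27300 nM

Compound 3 lies within the scatter of compound 2, and the numbers of both sit above that of compound 1, so compound 3 belongs to the weaker pair of this small set.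

Compound 4 `CC(O)(CSc1ccccc1C(F)(F)F)C(=O)Nc1cccc(S(F)(F)(F)(F)F)c1` has the same atoms as compound 3, joined differently: 2-(trifluoromethyl)phenyl in place of 4-(trifluoromethyl)phenyl on a sulfur. The change is on a sulfur whose other neighbour is a saturated chain carbon.

Among the measured compounds shown here, only one measured step comes close, a 1.1-fold higher number from compound 2 to compound 3 (0.05 log units; within the scatter). For the measured compounds named here, that step swaps one group for another on an aromatic carbon and stays within the scatter, but no measured pair shows a group moving in this way. Compound 1 differs from compound 4 in more than one place, so it is only a loose guide.

With so little evidence, no change beyond the scatter is expected, and the estimated step is a 1.2-fold lower number from compound 3 to compound 4 (0.09 log units; within the scatter).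

For compound 4 the expected value is 22000 nM, with an estimated range of 10000 nM to 45000 nM.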

Compound 4, half-maximal inhibitory concentration: 21000 nM
For compound 4 the middle estimate is 1.0-fold (0.02 log units) above the measured one; low and high end bracket the measured number.
By their numbers in this assay, from the lowest: compound 1; then compounds 4, 2 and 3 (each within the scatter of the next).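

In this assay, putting 2-(trifluoromethyl)phenyl in place of 4-(trifluoromethyl)phenyl on a sulfur gives a 1.3-fold lower number from compound 3 to compound 4 (0.11 log units; within the scatter). This is the first pair shown in which the atoms stay the same and only their joining differs, and the assay does not separate the two arrangements. So at this place on the sulfur, moving the trifluoromethyl group has no effect that can be told from the usual variation between repeated measurements, and nothing measured here bears on the reason.

The compounds shown leave open whether a different group on this phenyl ring, such as an amine, a nitrile or a carboxylic acid, would give a step beyond the scatter. They also leave open whether the same move would read alike on another core.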